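From phenyl to 2-methoxyphenyl at the assay limit

A few compounds are considered here, and "the series" means these few. Any claim that something is new, unique, unknown or untested is made for them only; others in the source may bear on it.

In a toxicity assay on THP-1 cells (Homo sapiens) for cytotoxicity (on this read-out lower numbers stand for an effect already at smaller amounts and higher numbers for an effect only at larger amounts of compound), compound 1 `CNc1ccnc2c(O)c(-c3nc(C)n[nH]3)ncc12` gives > 50100 nM as a limit of the assay. Compound 2 `Cc1n[nH]c(-c2ncc3c(N4CCCC4=O)ccnc3c2O)n1` gives > 50100 nM as a limit too. Compound 3 `Cc1n[nH]c(-c2ncc3c(-c4ccccc4)ccnc3c2O)n1` gives > 50100 nM and this is also a limit, so it has no number of its own. Among the measured compounds shown here, the series so far stands at the limit of > 50100 nM in this assay, at which 3 of the 3 values shown sit, and nothing finer.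

Compound 4 `COc1ccccc1-c1ccnc2c(O)c(-c3nc(C)n[nH]3)ncc12` differs from compound 3 by methoxy in place of hydrogen on an aromatic carbon on the phenyl ring, which becomes 2-methoxyphenyl. The measured steps offer a step that the two limits leave unreadable from compound 1 to compound 3 and a step that the two limits leave unreadable from compound 2 to compound 3 along with a step that the two limits leave unreadable from compound 1 to compound 2 and so give no size to carry over. No step beyond the scatter is expected in this assay and another limit is likely. The estimated change is a number no higher from compound 3 to compound 4 (the limit leaves the size open) in this reading. For compound 4 the expected value is 50100 nM with an estimated range of 25000 nM to 100000 nM in this assay.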

Compound 4, half-maximal effective concentration in the THP-1 assay: > 50100 nM
Compound 4 ended at the assay's limit (the forecaster's own chance of this, stated with the estimate: 85%); the middle value lies on the limit itself.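

In the THP-1 assay compound 4 gives > 50100 nM, which is a limit of the assay. In the THP-1 assay no step from compound 1, compound 2 or compound 3 to compound 4 can be read, as all four compounds share one limit: the limit of > 50100 nM in the THP-1 assay, at which 4 of the 4 values shown sit.

In a physicochemical assay for solubility, measured as kinetic solubility (on this read-out lower numbers stand for lower solubility and higher numbers for higher solubility), compound 3 gives 160000 nM. In the physicochemical assay compound 4 gives > 250000 nM, which is a limit of the assay. In the physicochemical assay methoxy in place of hydrogen on an aromatic carbon gives an at least 1.5-fold higher number from compound 3 to compound 4 (0.19 log units; that floor lies within the scatter).

The compounds shown leave open whether any substituent in this series changes cytotoxicity at all.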